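The compounds below may be only part of what the source reports. "The series", "measured", "known", "first", "only" and "open" are said of these compounds alone.

Measured in an ADME assay on MT4 cells (Homo sapiens) for cytotoxicity, read by MTT assay, with a stated time of 4 days; a lower number here means that less compound is tolerated, a higher number that more compound is tolerated:
- Compound 1 `Cc1cc(C#N)cc(C)c1Oc1ccnc(SCC(=O)Nc2ccc(C#N)cc2)n1`: > 300000 nM
- Compound 2 `Cc1ccc(NC(=O)CS(=O)(=O)c2nccc(Oc3c(C)cc(C#N)cc3C)n2)cc1`: 7490 nM
- Compound 3 `COc1ccc(NC(=O)CS(=O)(=O)c2nccc(Oc3c(C)cc(C#N)cc3C)n2)cc1`: 5110 nM

The read-out here is the half-maximal cytotoxic concentration. Compound 1 gives > 300000 nM, which is a limit of the assay and not a number. Going by the values given here, that leaves compound 2 and compound 3 as the only two actual numbers, and they lie within the scatter of each other. Compound 2, at 7490 nM, therefore marks a useful starting point.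

Compound 4 `Cc1cc(C#N)cc(C)c1Oc1ccnc(S(=O)(=O)CC(=O)Nc2ccccc2F)n1` has not yet been measured. It differs from compound 2 as follows: 2-fluorophenyl in place of 4-methylphenyl on an amide-type nitrogen. In words, it carries 2-fluorophenyl in place of 4-methylphenyl on an amide-type nitrogen.

Among the compounds with values here, only one measured step offers guidance, and it is a different swap: a 1.5-fold lower number from compound 2 to compound 3 (0.17 log units; within the scatter). There, methoxy takes the place of methyl on an aromatic carbon. That single small step gives no direction for the new change, so no shift beyond the scatter is expected in this assay. The estimated step is a 1.1-fold lower number from compound 2 to compound 4 (0.03 log units; within the scatter). With just one step to lean on, the range is kept wide. For compound 4 the expected value is 7000 nM, with an estimated range from 2500 nM to 25000 nM.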

Compound 4, half-maximal cytotoxic concentration: 28400 nM
Compound 4: the middle estimate sits 4.1-fold (0.61 log units) below what was measured; measured number outside the range, above it.
By their numbers in this assay, from the lowest: compounds 3 and 2 (each within the scatter of the next); then compound 4. At a limit, above all of these: compound 1.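

In this assay, the swap to 2-fluorophenyl on the amide-type nitrogen gives a 3.8-fold higher number from compound 2 to compound 4 (0.58 log units; beyond the scatter), and the same swap gives a 5.6-fold higher number from compound 3 to compound 4 (0.74 log units; beyond the scatter), so at this position the choice of aromatic group can move the number beyond the scatter. Going by these compounds alone, the only earlier step, methoxy in place of methyl on an aromatic carbon, gave a 1.5-fold lower number from compound 2 to compound 3 (0.17 log units; within the scatter), which offered no sign that changes in this part of the molecule could matter in either direction. Nothing given here explains why more of compound 4 is tolerated in this assay.

The swap removes a methyl and brings in a fluorine, and the two groups are named at different ring positions, so the compounds shown cannot separate the loss of the methyl, the presence of the fluorine and the position of the substituent. On these data alone, how a plain phenyl, a 4-fluorophenyl or a 2-chlorophenyl would fare on the same nitrogen stays open, and those three groups are the kind of comparison that could pull these effects apart.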